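The source may report more compounds than this note shows. Statements on the series, on what has been measured and on what is new or still open speak of the compounds shown alone.

Compound 3, with the structure `Cc1cc(O)c(C(=O)/C=C/c2ccc(Cl)cc2)c(-c2ccc(OCc3ccccc3)cc2)c1C(=O)/C=C/c1ccc(Cl)cc1`, stands highest of the three numbers recorded in a functional assay on MDA-MB-231 cells (Homo sapiens) for cytotoxicity, read by MTT assay, with a stated time of 24 h; on this read-out higher numbers stand for weaker inhibition and lower numbers for stronger inhibition: compound 3 gives 30000 nM. Compound 1, the structure `Cc1cc(O)c(C(=O)/C=C/c2ccc(Cl)cc2)c(-c2ccccc2)c1C(=O)/C=C/c1ccc(Cl)cc1`, gives in this assay 7900 nM, and compound 2, the structure `Cc1cc(O)c(C(=O)/C=C/c2ccc(Cl)cc2)c(-c2ccc(Br)cc2)c1C(=O)/C=C/c1ccc(Cl)cc1`, gives 15000 nM. The step from compound 3 to compound 4, the structure `Cc1cc(O)c(C(=O)/C=C/c2ccc(Cl)cc2)c(-c2ccc(Cl)cc2)c1C(=O)/C=C/c1ccc(Cl)cc1`, is chloro in place of benzyloxy on an aromatic carbon. Within the data shown here, two measured steps bear on it: a 3.8-fold higher number from compound 1 to compound 3 (0.58 log units; beyond the scatter), and a 2.0-fold higher number from compound 2 to compound 3 (0.30 log units; within the scatter). Both run towards compound 3, so walking away from compound 3 is read as a move towards lower numbers. The step in the reverse direction from bromo is the closer analogy, since chloro and bromo are both single halogen atoms, and that step lay within the scatter; the step from hydrogen lay beyond it. Compound 4 is therefore expected to sit between compound 2 and compound 1, with an expected step of a 2.5-fold lower number from compound 3 to compound 4 (0.40 log units; beyond the scatter). The estimate for compound 4 in this assay is 12000 nM, ranging from 5000 nM to 30000 nM.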

Compound 4, half-maximal inhibitory concentration: 30000 nM
The estimate for compound 4 lay 2.5-fold (0.40 log units) below the measured number; the measured number falls inside the stated range.
By their numbers in this assay, from the lowest: compounds 1, 2, 3 and 4 (each within the scatter of the next, the first and the last beyond it).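

In this assay, replacing benzyloxy with chloro, para to a large group, gave no change at the digits printed from compound 3 to compound 4 (within the scatter), so a single halogen atom and the far larger benzyloxy group read alike here. Chloro also gave a 2.0-fold higher number from compound 2 to compound 4 (0.30 log units; within the scatter), yet a different reading against hydrogen, with a 3.8-fold higher number from compound 1 to compound 4 (0.58 log units; beyond the scatter), places compound 4 with compound 3 beyond the scatter of compound 1, whereas compound 2, with bromo, goes against any simple rule that a halogen at this position separates from hydrogen. Nothing available explains why these groups read alike.

Going by these compounds, it remains open whether any group at this position can bring the number below that of compound 1. An amine, a hydroxyl or a carboxylic acid here would test whether only the hydrogen of compound 1 stands apart.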